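A few compounds are considered here, and "the series" means these few. Any claim that something is new, unique, unknown or untested is made for them only; others in the source may bear on it.

Compounds measured in an in vitro assay on HEK385-7 cells for displacement of a labelled ligand from prostaglandin D2 receptor 2 (Homo sapiens); a higher number here means a weaker inhibitor, a lower number a stronger inhibitor:
Compound 1, `O=C(O)Cc1sc(C(c2ccc(F)cc2)c2ccc(F)cc2)nc1-c1ccccc1`: 16 nM
Compound 2, `NS(=O)(=O)c1cccc(-c2nc(C(c3ccc(F)cc3)c3ccc(F)cc3)sc2CC(=O)O)c1`: 140 nM
Compound 3, `O=C(O)Cc1sc(C(c2ccc(F)cc2)c2ccc(F)cc2)nc1-c1ccncc1`: 5.3 nM

Compound 3 holds the lowest number of the three in this assay. Its nearest neighbour is compound 1, separated by a 3.0-fold lower number from compound 1 to compound 3 (0.48 log units; beyond the scatter), and its furthest is compound 2, separated by a 26-fold lower number from compound 2 to compound 3 (1.42 log units; beyond the scatter). Both steps lie beyond the scatter, so compound 3 is the strongest inhibitor among the measured compounds.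

Compound 4, `COc1cc(-c2nc(C(c3ccc(F)cc3)c3ccc(F)cc3)sc2CC(=O)O)ccn1`, has not yet been measured. It differs from compound 3 in one place: methoxy in place of hydrogen on an aromatic carbon. No measured step adds a methoxy to any of these compounds, so the change is only loosely anchored. The closest step in kind is an 8.8-fold higher number from compound 1 to compound 2 (0.94 log units; beyond the scatter), where a group was added to the ring of compound 1 that compound 3 later replaces, and that addition gave a modest loss. The other step, a 3.0-fold lower number from compound 1 to compound 3 (0.48 log units; beyond the scatter), exchanged the whole ring and says nothing about a group placed on it. On this thin basis a small loss, or no step beyond the scatter, is the more likely outcome. Compound 4 is expected to show a 1.5-fold higher number from compound 3 to compound 4 (0.18 log units; within the scatter) in this assay. For compound 4 the estimate is 8 nM, with a range from 2.5 nM to 25 nM.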

Compound 4, half-maximal inhibitory concentration: 29 nM
For compound 4 the middle estimate is 3.6-fold (0.56 log units) below the measured one; measured number outside the range, above it.
By their numbers in this assay, from the lowest: compound 3; then compounds 1 and 4 (each within the scatter of the next); then compound 2.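

In this assay, among the compounds shown here, the methoxy group gives the first direct reading of a substituent on the pyridin-4-yl ring: placed on the aromatic carbon next to the ring nitrogen, it gives a 5.5-fold higher number from compound 3 to compound 4 (0.74 log units; beyond the scatter) and so is not tolerated without cost at this position. It also cancels the advantage that pyridin-4-yl held over phenyl in a 3.0-fold lower number from compound 1 to compound 3 (0.48 log units; beyond the scatter). The comparison with the phenyl compound now gives a 1.8-fold higher number from compound 1 to compound 4 (0.26 log units; within the scatter), which leaves 2-methoxypyridin-4-yl and phenyl indistinguishable in this assay, while 2-methoxypyridin-4-yl still stands clear of 3-sulfamoylphenyl with a 4.8-fold lower number from compound 2 to compound 4 (0.68 log units; beyond the scatter) as the step. Nothing available here accounts for the loss on adding methoxy.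

The compounds shown leave open whether the loss belongs to methoxy itself or to any group on this carbon, a question that a methyl, a fluorine or an amine at the same place would address. They also leave open whether methoxy would cost as much on another carbon of the pyridin-4-yl ring, or on the phenyl ring of compound 1.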